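Replacing Phenyl with Benzyl on the Amide Nitrogen

A few compounds are considered here, and "the series" means these few. Any claim that something is new, unique, unknown or untested is made for them only; others in the source may bear on it.

Compound 1 `C=CC1=C(C(=O)NCc2ccccc2F)C(c2ccc(F)cc2)OC1` gives > 100000 nM in a functional assay on A549 cells (Homo sapiens) for cytotoxicity, read by MTT assay, with a stated time of 24 h; a lower number here means a stronger inhibitor, a higher number a weaker inhibitor; this value is a limit of the assay, not a measured number.
Compound 2 `C=CC1=C(C(=O)Nc2ccccc2)C(c2ccc(F)cc2)OC1` gives > 100000 nM in this assay; this value too is a limit of the assay.

Compound 2 therefore stands at the edge of what this assay can report: its value is a limit, and (the limit of > 100000 nM in this assay, at which 2 of the 2 values shown sit). Compound 3 `C=CC1=C(C(=O)NCc2ccccc2)C(c2ccc(F)cc2)OC1` has not yet been measured. It differs from compound 2 in one place: benzyl in place of phenyl on an amide-type nitrogen. Going by the values given here, only one measured step touches this change. The step that the two limits leave unreadable from compound 1 to compound 2 swaps a 2-fluorobenzyl for a phenyl on the same amide-type nitrogen, but both of its ends are limits, so its size cannot be read. Nothing in the two measured values gives a direction for adding a benzyl in place of the phenyl, and no step beyond the scatter is expected. Compound 3 is expected to give 150000 nM in this assay, with a range from 50000 nM to 500000 nM, most likely reported again as a limit. The expected step that the limit leaves unreadable from compound 2 to compound 3 is thus essentially none.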

Compound 3, half-maximal inhibitory concentration: > 100000 nM
Compound 3 was reported as a limit (the forecaster's own chance of this, stated with the estimate: 85%); the middle value is on the limit's open side.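

The steps linking compound 1, compound 2 and compound 3 cannot be read, because all three compounds end at the same limit of the assay: the limit of > 100000 nM in this assay, at which 3 of the 3 values shown sit.

The compounds shown leave open whether phenyl, benzyl and 2-fluorobenzyl on the amide-type nitrogen differ at all in this assay, and whether any compound with the shared core gives a measurable value there.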